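A few compounds are considered here, and "the series" means these few. Any claim that something is new, unique, unknown or untested is made for them only; others in the source may bear on it.

Measured so far in a functional assay on A549 cells (Homo sapiens) for cytotoxicity, read by sulforhodamine B assay; on this read-out lower numbers stand for stronger inhibition and higher numbers for weaker inhibition:

Compound 1, `C=C1[C@@H](OC(C)=O)C[C@@H]2[C@](C)(COC=O)[C@H](OC(C)=O)CC[C@@]2(C)[C@@H]1C[C@@H](Nc1ccc(Br)cc1)C1=CCOC1=O`: 15900 nM
Compound 2, `C=C1[C@@H](OC(C)=O)C[C@@H]2[C@](C)(CO[Si](C)(C)C(C)(C)C)[C@H](OC(C)=O)CC[C@@]2(C)[C@@H]1C[C@@H](Nc1ccc(OC)cc1)C1=CCOC1=O`: 4810 nM
Compound 3, `C=C1[C@@H](OC(C)=O)C[C@@H]2[C@](C)(COC=O)[C@H](OC(C)=O)CC[C@@]2(C)[C@@H]1C[C@@H](Nc1ccc(OC)c(OC)c1)C1=CCOC1=O`: compound 3 gives only a limit of the assay, > 50000 nM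

Compound 2 stands lowest of the two numbers in this assay; compound 1 is the nearest, with a higher number. Compound 3 sits at the limit, (the limit of > 50000 nM in this assay, at which 1 of the 3 values shown sits). Among the measured compounds shown here, the only step in which two measured compounds differ at one place is an at least 3.1-fold higher number from compound 1 to compound 3 (0.49 log units; beyond the scatter), a weakening that follows a change of the aryl group on the amine nitrogen.

Compound 4 is `C=C1[C@@H](OC(C)=O)C[C@@H]2[C@](C)(CO[Si](C)(C)C(C)(C)C)[C@H](OC(C)=O)CC[C@@]2(C)[C@@H]1C[C@@H](Nc1cccc2ccccc12)C1=CCOC1=O`. It differs from compound 2 by naphthalen-1-yl in place of 4-methoxyphenyl on an amine nitrogen. The measured step bears on it only loosely: it concerns the same place, but a different aryl group, and the compounds involved also carry a different chain on the shared core. It shows that changes on the amine nitrogen can move this assay considerably, yet gives no direction for naphthalen-1-yl. A step no larger than a modest one, in either direction, is expected, a 1.9-fold higher number from compound 2 to compound 4 (0.27 log units; within the scatter). Compound 4 is expected to give about 9000 nM in this assay, with a range from 3000 nM to 30000 nM.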

Compound 4, half-maximal inhibitory concentration: 4970 nM
The estimate for compound 4 lay 1.8-fold (0.26 log units) above the measured number, and the stated range covers the measured number.
By their numbers in this assay, from the lowest: compounds 2 and 4 (each within the scatter of the next); then compound 1. At a limit, above all of these: compound 3.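

In this assay, among the compounds shown here, the step of a 1.0-fold higher number from compound 2 to compound 4 (0.01 log units; within the scatter) is the first on the amine nitrogen with a number at both ends rather than a limit at one. Naphthalen-1-yl, with its second six-membered aromatic ring and no hydrogen-bond acceptor, therefore takes the place of 4-methoxyphenyl on this chain without a reading of change, whereas the earlier step at this place, an at least 3.1-fold higher number from compound 1 to compound 3 (0.49 log units; beyond the scatter), lay beyond the scatter. Nothing measured here accounts for this result.

Open, going by these compounds, is whether a plain phenyl, a benzyl or a cyclohexyl on the amine nitrogen would read the same way. Also open, on these data alone, is whether naphthalen-1-yl would read the same with the formyloxymethyl chain of compound 1 in place of the chain carried by compound 2 and compound 4.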